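Adding methoxy to compound 2

A few compounds are considered here, and "the series" means these few. Any claim that something is new, unique, unknown or untested is made for them only; others in the source may bear on it.

Compound 1 `Cc1ccc(Nc2c(NCCCCCC(=O)NO)c(=O)c2=O)cc1` gives 1800000 nM as measured
Compound 2 `CN(C)c1ccc(Nc2c(NCCCCCC(=O)NO)c(=O)c2=O)cc1` gives 1400000 nM as measured
Compound 3 `COc1cc(Nc2c(NCCCCCC(=O)NO)c(=O)c2=O)ccc1N(C)C` is still unmeasured

For the measured compounds named here, in a physicochemical assay for solubility, with a stated time of 24 h, tested at 30 mg/mL (on this read-out lower numbers stand for lower solubility and higher numbers for higher solubility), compound 2 gives 1400000 nM and stands within the usual scatter of compound 1 at 1800000 nM as the only other measured compound. Compound 3 differs from compound 2 in one place: methoxy in place of hydrogen on an aromatic carbon with methoxy in place of hydrogen on an aromatic carbon. Going by the values given here, the only measured step of a 1.3-fold lower number from compound 1 to compound 2 (0.11 log units; within the scatter) stayed within the scatter. It changed a different group and is only a loose guide, so no step beyond the scatter is expected in this assay here. The expected step is a 1.2-fold lower number from compound 2 to compound 3 (0.07 log units; within the scatter) in size. For compound 3 the estimated value is 1200000 nM with an expected range from 500000 nM to 2500000 nM for now.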

Compound 3, solubility: 2600000 nM
For compound 3 the middle estimate is 2.2-fold (0.34 log units) below the measured one; the whole stated range lies below it.
By their numbers in this assay, from the lowest: compounds 2, 1 and 3 (each within the scatter of the next).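

In this assay, methoxy on the aromatic carbon ortho to a dimethylamino group gives a 1.9-fold higher number from compound 2 to compound 3 (0.27 log units; within the scatter) and so leaves compound 3 within the scatter of compound 2. The position therefore takes a group of 2 heavy atoms, with the dimethylamino group kept in place, without a step beyond the scatter. Nothing available explains this result.

From the compounds shown here alone, whether an ethoxy group, an amine or a carboxylic acid on the same carbon would also stay within the scatter remains open.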